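Thiophene in place of ethyne on a deazapurine nucleoside core

The source may hold more compounds than are shown below. What is called first, only, known or untested is meant among the compounds shown, and "the series" means these compounds.

Compounds measured so far:
compound 1 `C#Cc1cn([C@@H]2O[C@H](CO)[C@@H](O)[C@H]2O)c2ncnc(N(C)C)c12`: 180 nM
compound 2 `C#Cc1cn([C@@H]2O[C@H](CO)[C@@H](O)[C@H]2O)c2ncnc(NC)c12`: > 20000 nM
compound 3 `C#Cc1cn([C@@H]2O[C@H](CO)[C@@H](O)[C@H]2O)c2ncnc(OC)c12`: 4060 nM

In a functional assay on HCT-116 cells (Homo sapiens), read by MTT assay, with a stated time of 72 h (on this read-out higher numbers stand for weaker inhibition and lower numbers for stronger inhibition), compound 1 gives 180 nM. Compound 2 gives only a limit of this assay, > 20000 nM, and so stands at the limit of > 20000 nM in this assay, at which 1 of the 3 values shown sits. Compound 3 gives 4060 nM. Compound 1 thus has the lowest of the two numbers shown, and the nearest number, that of compound 3, lies a 23-fold higher number from compound 1 to compound 3 (1.35 log units; beyond the scatter); the step of an at least 110-fold higher number from compound 1 to compound 2 (2.04 log units; beyond the scatter) is larger still. Both of these steps change the group on the aromatic carbon that carries dimethylamino, methylamino or methoxy.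

Compound 4 `CN(C)c1ncnc2c1c(-c1cccs1)cn2[C@@H]1O[C@H](CO)[C@@H](O)[C@H]1O` differs from compound 1 elsewhere: thiophen-2-yl in place of ethynyl on an aromatic carbon. No measured step touches this position, so none of the steps shown bear directly on it. With the dimethylamino group kept as in compound 1, no step beyond the scatter in this assay is expected in either direction, though the uncertainty is wide. Compound 4 is therefore estimated at 250 nM, within 40 nM to 3000 nM, which would mean an expected step of a 1.4-fold higher number from compound 1 to compound 4 (0.14 log units; within the scatter).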

Compound 4, half-maximal inhibitory concentration: > 20000 nM
Compound 4 was reported as a limit; the forecaster's own chance of this, stated with the estimate: 8%; middle value at least 80-fold (1.90 log units) from the limit.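

In this assay, this aromatic carbon proves far from indifferent to change: with the dimethylamino group kept, thiophen-2-yl in place of ethynyl gives an at least 110-fold higher number from compound 1 to compound 4 (2.04 log units; beyond the scatter). Compound 4 gives > 20000 nM, which is a limit of the assay and not a number, so the full size of this step cannot be read: the limit of > 20000 nM in this assay, at which 2 of the 4 values shown sit. The earlier steps shown here tied the low number of compound 1 to the dimethylamino group alone, whereas it now also depends on the group at this second place.

As far as these compounds go, it remains open how a smaller group such as methyl or chloro, or another ring such as furan-2-yl or phenyl, would read on this carbon. From the compounds shown here alone, it is also open whether thiophen-2-yl would read differently with methoxy in place of dimethylamino.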